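This account rests on a few compounds, and the source may have more. Where it says the series, first, only, none or still open, it means among the compounds named here.

Measured so far in a toxicity assay on GES1 cells (Homo sapiens) for inhibition, read by MTT assay, with a stated time of 72 h; a lower number here means a stronger inhibitor, a higher number a weaker inhibitor:
- compound 1 `Cc1cc(N2CC[C@@H](C)[C@@H](N(C)c3ncnc4[nH]ccc34)C2)n2nc(SCc3nc4ccccc4[nH]3)nc2n1`: 40200 nM
- compound 2 `COc1ccc(CSc2nc3nc(C)cc(N4CC[C@@H](C)[C@@H](N(C)c5ncnc6[nH]ccc56)C4)n3n2)cc1`: > 100000 nM

In this assay compound 2 gives > 100000 nM, which is a limit of the assay and not a number. Among the compounds with values here, the series so far therefore shows (the limit of > 100000 nM in this assay, at which 1 of the 2 values shown sits).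

Compound 3 `Cc1cc(N2CC[C@@H](C)[C@@H](N(C)c3ncnc4[nH]ccc34)C2)n2nc(SCc3ccc([N+](=O)[O-])cc3)nc2n1` keeps the shared core and the sulfanyl link of compound 2 and changes one group, from 4-methoxyphenyl to 4-nitrophenyl: nitro in place of methoxy on an aromatic carbon. Within the data shown here, only one measured step bears on this change, an at least 2.4-fold higher number from compound 1 to compound 2 (0.39 log units; beyond the scatter). From the compounds shown here alone, that step is beyond the scatter, but it is open-ended and replaces the whole group on the chain carbon, whereas here only a substituent on the aromatic ring changes. Among the measured compounds shown here, no measured step exchanges such a substituent, so its size can only be a loose guide. For the measured compounds named here, the sole numerical value, that of compound 1 at 40200 nM, is itself weak, so compound 3 is expected to remain weak in this assay. Only a modest change is expected, estimated as an at least 1.3-fold lower number from compound 2 to compound 3 (0.12 log units; that floor lies within the scatter). The estimate for compound 3 is 75000 nM, with an expected range from 30000 nM to 150000 nM.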

Compound 3, half-maximal inhibitory concentration: 36600 nM
Estimate against measurement, compound 3: 2.0-fold (0.31 log units) above; measured number inside the range.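

In this assay, nitro in place of methoxy on an aromatic carbon, para to a large group, gives an at least 2.7-fold lower number from compound 2 to compound 3 (0.43 log units; beyond the scatter), which shows that exchanging this one substituent can move the read-out beyond the scatter, whereas the earlier step replaced the whole group on the chain carbon. Compound 2 gives > 100000 nM, which is a limit of the assay and not a number, so this step has only a floor: the limit of > 100000 nM in this assay, at which 1 of the 3 values shown sits. The exchange of the 1H-benzimidazol-2-yl group for 4-nitrophenyl on the chain carbon gives a 1.1-fold lower number from compound 1 to compound 3 (0.04 log units; within the scatter), so these two groups are not told apart here, and of the three groups shown only 4-methoxyphenyl stands apart from the others.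

Only methoxy and nitro are shown on this aromatic carbon, so two substituents leave open how an amine, a chlorine or a carboxylic acid in the same place would read. Also open, from the compounds shown here alone, is how the read-out would respond to a longer chain between the sulfur and the ring.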